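The compounds below may be only part of what the source reports. "The series", "measured", "known", "first", "only" and "open" are said of these compounds alone.

Within the data shown here, compound 1 `Cc1c(C2CC2)nc2ccc(-n3ccc(OCc4ccc(F)cc4)cc3=O)cn12` gives 47 nM in an assay on CHO cells for displacement of a labelled ligand from melanin-concentrating hormone receptor 1 (Homo sapiens), read by scintillation counting, with a stated time of 1 h (a lower number here means a stronger inhibitor, a higher number a weaker inhibitor), and that is the only true number among the three measured values. Compound 2 `Cc1c(CO)nc2ccc(-n3ccc(OCc4ccc(F)cc4)cc3=O)cn12` reaches in this assay only the limit of > 1000 nM. Compound 3 `COCc1nc2ccc(-n3ccc(OCc4ccc(F)cc4)cc3=O)cn2c1C` likewise reaches only the limit of > 1000 nM. The steps of an at least 21-fold higher number from compound 1 to compound 2 (1.32 log units; beyond the scatter) and an at least 21-fold higher number from compound 1 to compound 3 (1.32 log units; beyond the scatter) both exchange the cyclopropyl, and the pair compound 2 to compound 3 shows a step that the two limits leave unreadable from compound 2 to compound 3 since both values sit at the limit of > 1000 nM in this assay, at which 2 of the 3 values shown sit. Compound 4 `Cc1c(C2CC2)nc2ccc(-n3ccc(OCc4cncnc4)cc3=O)cn12` keeps the cyclopropyl and instead carries pyrimidin-5-yl in place of 4-fluorophenyl on a saturated chain carbon bound to an oxygen on an aromatic ring. Among the measured compounds shown here, no measured step touches this part of the molecule, so none bears directly on the change. A modest weakening is expected, a 3.2-fold higher number from compound 1 to compound 4 (0.50 log units; beyond the scatter). Compound 4 is therefore estimated at 150 nM, with a range from 40 nM to 600 nM.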

Compound 4, half-maximal inhibitory concentration: > 1000 nM
Compound 4: only a limit was reported; the forecaster's own chance of this, stated with the estimate: 10%; at least 6.6-fold (0.82 log units) between middle value and limit.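

The earlier steps shown here touched only the cyclopropyl; this one shows that the 4-fluorophenyl on the saturated chain carbon also counts in this assay, with an at least 21-fold higher number from compound 1 to compound 4 (1.32 log units; beyond the scatter) on placing pyrimidin-5-yl there. Compound 4 gives > 1000 nM as a limit and not a number, so the full size of this step cannot be read: the limit of > 1000 nM in this assay, at which 3 of the 4 values shown sit.

The compounds shown leave open whether the loss follows the removal of the fluorine or the entry of the two ring nitrogens. An unsubstituted phenyl or a pyridin-3-yl at this place would help separate the two.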